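Extending the branched alkoxy chain on the shared core

The compounds below may be only part of what the source reports. "The series", "measured", "known", "first", "only" and "open" are said of these compounds alone.

Of the compounds shown here, two sharing one core have been measured. Compound 1 `CCCCCOc1ccc(C(CC(=O)O)c2ccccc2)cc1` gives 2.97 uM in a functional assay on HEK293 cells for agonist activity at Free fatty acid receptor 1 (Homo sapiens), read by calcium flux (on this read-out higher numbers stand for an effect only at larger amounts of compound and lower numbers for an effect already at smaller amounts), and compound 2 `CC(C)CCOc1ccc(C(CC(=O)O)c2ccccc2)cc1` gives 1.86 uM. Among the compounds with values here, the single step between them, a 1.6-fold lower number from compound 1 to compound 2 (0.20 log units; within the scatter), leaves the two within the scatter of each other, so compound 2 stands beside compound 1 rather than apart from it. Compound 3 `CCC(CC)COc1ccc(C(CC(=O)O)c2ccccc2)cc1` is not yet measured. It differs from compound 2 by pentan-3-yl in place of isobutyl on a saturated chain carbon bound to an oxygen on an aromatic ring, that is, isopentyloxy becomes 2-ethylbutoxy. Within the data shown here, the only measured step that bears on this is the one from compound 1 to compound 2, a change of branching on the same chain, and it was within the scatter. A similar outcome is therefore expected for compound 3, with no step beyond the scatter: a 1.2-fold lower number from compound 2 to compound 3 (0.07 log units; within the scatter). Compound 3 is estimated to give 1.6 uM in this assay, in the range 0.6 uM to 4.5 uM.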

Compound 3, concentration for half-maximal effect: 0.64 uM
The estimate for compound 3 lay 2.5-fold (0.40 log units) above the measured number; the measured number falls inside the stated range.
By their numbers in this assay, from the lowest: compound 3; then compounds 2 and 1 (each within the scatter of the next).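

In this assay, the change from isobutyl to pentan-3-yl on a saturated chain carbon bound to an oxygen on an aromatic ring gives a 2.9-fold lower number from compound 2 to compound 3 (0.46 log units; beyond the scatter), so this position does respond to the shape and size of the chain, which the earlier step within the scatter did not show. Pentan-3-yl in place of butyl at the same place gives a 4.6-fold lower number from compound 1 to compound 3 (0.67 log units; beyond the scatter), which sets compound 3 apart from both earlier compounds, while those two remain within the scatter of each other. Nothing measured here accounts for this difference.

As far as these compounds go, it remains open whether a still larger branched group such as 2-propylpentyl would lower the number further or raise it again. The effect of a ring at this place, such as cyclopentyl, is also unknown.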